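Swapping Bromo for Carboxy on Compound 2

This account rests on a few compounds, and the source may have more. Where it says the series, first, only, none or still open, it means among the compounds named here.

Three compounds have been measured in a functional assay on HCT-116 cells (Homo sapiens) for cytotoxicity, read by MTT assay, with a stated time of 48 h; a higher number here means a weaker inhibitor, a lower number a stronger inhibitor:

Compound 1 `O=C(/C=C/c1ccc2c(c1)B(O)OC2)c1cccnc1`: 20500 nM
Compound 2 `O=C(/C=C/c1ccc2c(c1)B(O)OC2)c1ccc(Br)cc1`: 9900 nM
Compound 3 `O=C(/C=C/c1ccc2c(c1)B(O)OC2)c1ccccc1O`: 77900 nM

Compound 2 gives the lowest number of the three, and both gaps lie beyond the scatter: a 2.1-fold lower number from compound 1 to compound 2 (0.32 log units; beyond the scatter), and a 7.9-fold higher number from compound 2 to compound 3 (0.90 log units; beyond the scatter). So the group on the carbonyl carbon clearly matters, yet every measured swap replaces the whole ring, never a single substituent on it.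

Compound 4 `O=C(O)c1ccc(C(=O)/C=C/c2ccc3c(c2)B(O)OC3)cc1` differs from compound 2 by carboxy in place of bromo on an aromatic carbon. Among the compounds with values here, no measured step exchanges bromo for carboxy, so the data give no direct guide to its size. Given that each departure from compound 2 so far has raised the number, a modest rise is expected; for compound 4 the expected step is a 3.0-fold higher number from compound 2 to compound 4 (0.48 log units; beyond the scatter). Compound 4 is therefore estimated at 30000 nM, with a range from 8000 nM to 120000 nM.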

Compound 4, half-maximal inhibitory concentration: > 100000 nM
Compound 4: no number, only a limit; the forecaster's own chance of this, stated with the estimate: 10%; at least 3.3-fold (0.52 log units) between middle value and limit.
By their numbers in this assay, from the lowest: compound 2; then compound 1; then compound 3. At a limit, above all of these: compound 4.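

In this assay compound 4 gives > 100000 nM, which is a limit of the assay and not a number. Unlike the earlier steps, which replaced the whole ring, this one keeps the ring and changes a single substituent, on an aromatic carbon para to a large group: an at least 10-fold higher number from compound 2 to compound 4 (1.00 log units; beyond the scatter). So one group at this place is enough to move the number well beyond the scatter, upward.

As far as these compounds go, the true size of the step stays open. So does how an amine, a methyl ester or a chloro group would read at this same place.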